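The source may report more compounds than this note shows. Statements on the series, on what has been measured and on what is new or still open speak of the compounds shown alone.

Measured so far in a functional assay on U-87MG ATCC cells for antiproliferative activity against U-87 MG (Homo sapiens), read by MTT assay, with a stated time of 48 h, tested at 100 uM; on this read-out higher numbers stand for a weaker effect at the one concentration tested and lower numbers for a stronger effect:
compound 1 `Cc1nc(-c2ccc(Cl)cc2)sc1C(=O)CSc1nc(-c2ccccc2)c(C#N)c(=O)[nH]1` gives 11.4%;
compound 2 `Cc1nc(-c2ccc(Cl)cc2)sc1C(=O)CSc1nc(-c2ccc(Cl)c(Cl)c2)c(C#N)c(=O)[nH]1` gives 36.5%;
compound 3 `COc1ccc(-c2nc(SCC(=O)c3sc(-c4ccc(Cl)cc4)nc3C)[nH]c(=O)c2C#N)cc1` gives 16.6%.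

Compound 3 stands second highest of the three numbers: its value sits within the scatter of that of compound 1, while the step of a number 19.9 percentage points lower from compound 2 to compound 3 (beyond the scatter) lies beyond the scatter. Compound 4 `COc1cccc(-c2nc(SCC(=O)c3sc(-c4ccc(Cl)cc4)nc3C)[nH]c(=O)c2C#N)c1` differs from compound 3 in one place: 3-methoxyphenyl in place of 4-methoxyphenyl on an aromatic carbon. Of the measured steps, only a number 5.2 percentage points higher from compound 1 to compound 3 (within the scatter) touches the methoxy group at all, and it was within the scatter; the larger step of a number 25.1 percentage points higher from compound 1 to compound 2 (beyond the scatter) concerns 3,4-dichlorophenyl and does not bear on moving a methoxy group. For the measured compounds named here, no measured pair tests 3-methoxyphenyl against 4-methoxyphenyl. The expected step of a number 1.4 percentage points higher from compound 3 to compound 4 (within the scatter) is therefore none beyond the scatter. Compound 4 is estimated at 18%, with a range from 8% to 32%.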

Compound 4, a percentage reported as activity, at one concentration (the size of the read-out at that concentration, not a potency): 8.54%
The estimate for compound 4 lay 9.5 percentage points above the measured number; the measured number falls inside the stated range.
By their numbers in this assay, from the lowest: compounds 4, 1 and 3 (each within the scatter of the next); then compound 2.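

In this assay, the shift from 4-methoxyphenyl to 3-methoxyphenyl gives a number 8.1 percentage points lower from compound 3 to compound 4 (within the scatter) and so separates neither methoxy placement at this position, while the comparison with phenyl gives a number 2.9 percentage points lower from compound 1 to compound 4 (within the scatter) and shows the same for 3-methoxyphenyl. The change from 3,4-dichlorophenyl gives a number 28 percentage points lower from compound 2 to compound 4 (beyond the scatter) and leaves compound 2 apart from the other three compounds. No available measurement accounts for this gap.

Still open, from the compounds shown here alone, is whether one chlorine alone reproduces the 3,4-dichlorophenyl result. An amine or a carboxylic acid on this phenyl ring also remains untested in the compounds shown here.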